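Predicting a Chloro Removal in a Cell Growth Assay

The source may hold more compounds than are shown below. What is called first, only, known or untested is meant among the compounds shown, and "the series" means these compounds.

Measured in a functional assay on HeLa cells (Homo sapiens) for antiproliferative activity, read by MTT assay, with a stated time of 48 h; on this read-out higher numbers stand for weaker inhibition and lower numbers for stronger inhibition:
Compound 1, `O=C(CCCl)Nc1ccc(SCC(=O)Nc2cc(Cl)ccn2)cc1`, gives 21700 nM.
Compound 2, `O=C(CCCl)Nc1ccc(SCC(=O)Nc2ccccn2)cc1`, gives 70400 nM.
Compound 3, `C=CC(=O)Nc1ccc(SCC(=O)Nc2cc(Cl)ccn2)cc1`, gives 25200 nM.

Compound 4, `C=CC(=O)Nc1ccc(SCC(=O)Nc2ccccn2)cc1`, has not yet been measured in this assay.

Compound 1 and compound 2 differ in one place: hydrogen in place of chloro on an aromatic carbon. That change gave a 3.2-fold higher number from compound 1 to compound 2 (0.51 log units; beyond the scatter). Compound 3 and compound 4 differ by the same change, (hydrogen in place of chloro on an aromatic carbon), made at the same place on the same kind of ring. The cores of compound 1 and compound 3 themselves differ as vinyl in place of 2-chloroethyl on a carbonyl carbon, and that difference gave a 1.2-fold higher number from compound 1 to compound 3 (0.06 log units; within the scatter), so the two cores behave alike in this assay as far as the data go.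

The only guide to what compound 4 will do is the single earlier example, since the removal of the chloro occurs just twice among these compounds. Because compound 3 and compound 1 are within the scatter of each other, a 1.2-fold higher number from compound 1 to compound 3 (0.06 log units; within the scatter), and the chloro removal on the core of compound 1 gave a 3.2-fold higher number from compound 1 to compound 2 (0.51 log units; beyond the scatter), the step from compound 3 to compound 4 is expected to be of similar size, a 3.0-fold higher number from compound 3 to compound 4 (0.47 log units; beyond the scatter). The estimate for compound 4 in this assay is therefore 75000 nM, expected to fall between 35000 nM and 160000 nM.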

Compound 4, half-maximal inhibitory concentration: > 80000 nM
Compound 4 was reported as a limit (the forecaster's own chance of this, stated with the estimate: 15%); middle value at least 1.0-fold (0.02 log units) away from the limit.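

In this assay compound 4 gives > 80000 nM, which is a limit of the assay and not a number. On the core of compound 3, the swap of chloro for hydrogen gave an at least 3.1-fold higher number from compound 3 to compound 4 (0.50 log units; beyond the scatter), so the loss of the chloro weakens inhibition on both cores, although the second step is bounded from one side only and its true size stays unknown: the same change on two cores in this assay, a 3.2-fold higher number (0.51 log units; beyond the scatter) from compound 1 to compound 2 and an at least 3.1-fold higher number (0.50 log units; beyond the scatter) from compound 3 to compound 4; the limit leaves it open whether they differ The swap of 2-chloroethyl for vinyl, read on the compounds that carry pyridin-2-yl, gave an at least 1.1-fold higher number from compound 2 to compound 4 (0.05 log units; that floor lies within the scatter), which does not show that the two cores part ways once the chloro is gone, nor that they stay alike: the same change on two cores in this assay, a 1.2-fold higher number (0.06 log units; within the scatter) from compound 1 to compound 3 and an at least 1.1-fold higher number (0.05 log units; that floor lies within the scatter) from compound 2 to compound 4; the limit leaves it open whether they differ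

The compounds shown leave open whether the pattern reaches beyond these two cores, since it rests on one pair of steps, one of them ending at a limit. They also leave open how a bromo, a methoxy group or an amine would compare with the chloro at the same place on the ring, and how a longer chain would compare with the vinyl or the 2-chloroethyl on the carbonyl carbon.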